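Extending the ester into a pyridine ring on the oxazole

This account rests on a few compounds, and the source may have more. Where it says the series, first, only, none or still open, it means among the compounds named here.

Compound 1 `COC(=O)c1cc(-c2cnc(C(=O)CCc3ccc(-c4ccccc4)cc3)o2)ccn1`: 1.5 nM
Compound 2 `O=C(O)c1ccc(-c2cnc(C(=O)CCc3ccc(-c4ccccc4)cc3)o2)nc1`: 14 nM
Compound 3 `COC(=O)c1cnc(C(=O)CCc2ccc(-c3ccccc3)cc2)o1`: 1.5 nM

In an assay for inhibition of Fatty-acid amide hydrolase 1 (Rattus norvegicus) (on this read-out higher numbers stand for weaker inhibition and lower numbers for stronger inhibition), compound 3 gives 1.5 nM, level with compound 1 and clearly stronger than compound 2, as a 9.3-fold lower number from compound 2 to compound 3 (0.97 log units; beyond the scatter) shows. Compound 4 `COC(=O)c1cccc(-c2cnc(C(=O)CCc3ccc(-c4ccccc4)cc3)o2)n1` differs from compound 3 by 6-(methoxycarbonyl)pyridin-2-yl in place of methoxycarbonyl on an aromatic carbon. Within the data shown here, two measured steps bear on this. The step of no change at the digits printed from compound 1 to compound 3 (within the scatter) shows that a methyl ester and a pyridine bearing a methyl ester can give the same number, while a 9.3-fold lower number from compound 2 to compound 3 (0.97 log units; beyond the scatter) shows that a pyridine bearing a free acid weakens inhibition. Compound 4 keeps the methyl ester, so the expected step is small, a 1.3-fold higher number from compound 3 to compound 4 (0.12 log units; within the scatter), within the scatter. Compound 4 is therefore estimated at 2 nM, likely between 0.7 nM and 6 nM.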

Compound 4, inhibition constant: 1.2 nM
For compound 4 the middle estimate is 1.7-fold (0.22 log units) above the measured one, within the range that was stated.
By their numbers in this assay, from the lowest: compounds 4, 1 and 3 (each within the scatter of the next); then compound 2.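

On this aromatic carbon next to the ring oxygen, 6-(methoxycarbonyl)pyridin-2-yl serves as well as a bare methoxycarbonyl, a 1.3-fold lower number from compound 3 to compound 4 (0.10 log units; within the scatter), and as well as the other ester-bearing pyridine, a 1.3-fold lower number from compound 1 to compound 4 (0.10 log units; within the scatter). Only the pyridine carrying a free acid stands apart, a 12-fold lower number from compound 2 to compound 4 (1.07 log units; beyond the scatter), although the acid and ester also sit differently on their pyridine rings. No supporting evidence accounts for these numbers. From the compounds shown here alone, how an amide or a nitrile in place of the methyl ester on this pyridine would score remains open.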